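The source may report more compounds than this note shows. Statements on the series, on what has been measured and on what is new or still open speak of the compounds shown alone.

Measured in a functional assay on MCF7 cells (Homo sapiens) for antiproliferative activity, read by sulforhodamine B assay, with a stated time of 3 days; on this read-out higher numbers stand for weaker inhibition and lower numbers for stronger inhibition:
compound 1 `Fc1ccc(Sc2ncnc3c2ncn3C2COc3ccccc3CO2)cc1`: 11200 nM
compound 2 `CSc1ncnc2c1ncn2C1COc2ccccc2CO1`: 24000 nM
compound 3 `Fc1ccc(Sc2ncnc3ncn(C4COc5ccccc5CO4)c23)cc1`: 14100 nM

Compound 1 and compound 3 contain the same atoms joined differently; the difference between the two cores is not broken down here, and their numbers in this assay lie within the scatter of each other. Compound 2 differs from compound 1 by methyl in place of 4-fluorophenyl on a sulfur, and this gave a 2.1-fold higher number from compound 1 to compound 2 (0.33 log units; beyond the scatter).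

Compound 4 `CSc1ncnc2ncn(C3COc4ccccc4CO3)c12` is not yet measured. It differs from compound 3 by methyl in place of 4-fluorophenyl on a sulfur; the place reads the same as for the earlier pair, so this is the same change on the other core. Among the measured compounds shown here, the step from compound 3 to compound 4 is expected to be about a 2.1-fold higher number from compound 3 to compound 4 (0.33 log units; beyond the scatter) because the same change gave a 2.1-fold higher number from compound 1 to compound 2 (0.33 log units; beyond the scatter), the only precedent here. Compound 4 is therefore estimated at 30000 nM in this assay, with a range of 15000 nM to 60000 nM.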

Compound 4, half-maximal inhibitory concentration: 31800 nM
Estimate against measurement, compound 4: 1.1-fold (0.03 log units) below; low and high end bracket the measured number.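

In this assay, methyl in place of 4-fluorophenyl on a sulfur gives a 2.3-fold higher number from compound 3 to compound 4 (0.35 log units; beyond the scatter) and the step keeps its size on the second core: the same change on two cores in this assay, a 2.1-fold higher number (0.33 log units; beyond the scatter) from compound 1 to compound 2 and a 2.3-fold higher number (0.35 log units; beyond the scatter) from compound 3 to compound 4, 1.1-fold (0.02 log units) apart, within the scatter of two such steps

This shows that the step carried over between these two cores, but it rests on one change and one pair per core. It does not show that the step would hold on any other core, or for any other group on the sulfur, and it gives no reason for the step.

Open, on these data alone, is whether a phenyl without fluorine on the sulfur would read like 4-fluorophenyl or like methyl. Also open, as far as these compounds go, is how a longer alkyl chain on the sulfur, or an amine in place of the sulfur, would read on either core.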